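Cytotoxicity notes: from compound 1 toward compound 3

A few compounds are considered here, and "the series" means these few. Any claim that something is new, unique, unknown or untested is made for them only; others in the source may bear on it.

Measured so far in a functional assay on HEK293 cells (Homo sapiens) for cytotoxicity; on this read-out higher numbers stand for lower toxicity in this test and lower numbers for higher toxicity in this test:
compound 1 `COc1ccc([C@H]2CC(=O)N(Cc3cccc([N+](=O)[O-])c3)C2)cc1OC1CCCC1` — > 10000 nM
compound 2 `COc1ccc([C@H]2CC(=O)N(c3ccccc3)C2)cc1OC1CCCC1` — > 10000 nM

The value of compound 1 is a limit of the assay, not a number. The value of compound 2 is likewise a limit. The step that the two limits leave unreadable from compound 1 to compound 2 is therefore unreadable in size and direction, as the limit of > 10000 nM in this assay, at which 2 of the 2 values shown sit, records. Going by the values given here, compound 1 thus stands at the limit itself, and no measured step from it can be read.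

The unmeasured compound 3 `COc1ccc([C@H]2CC(=O)N(c3ccc(C)c(N)c3)C2)cc1OC1CCCC1` differs from compound 1 as follows: 3-amino-4-methylphenyl in place of 3-nitrobenzyl on an amide-type nitrogen in a ring. Among the compounds with values here, the only measured step, a step that the two limits leave unreadable from compound 1 to compound 2, also exchanges the 3-nitrobenzyl on the same ring nitrogen for an aryl group and gave no readable size, so no step bears on the change with a known magnitude. In this assay compound 3 is therefore expected to remain at the limit as well, the estimated step that the limit leaves unreadable from compound 1 to compound 3 staying within the usual scatter should a number ever be obtained. The estimate for compound 3 is 20000 nM, with a range from 8000 nM to 60000 nM.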

Compound 3, half-maximal cytotoxic concentration: > 10000 nM
Compound 3 ended at the assay's limit; the forecaster's own chance of this, stated with the estimate: 80%; the middle value does not contradict the limit.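

Compound 3 sits at the same limit as compound 1 and compound 2 in this assay, so no step among these compounds can be read in size or direction: the limit of > 10000 nM in this assay, at which 3 of the 3 values shown sit. The compounds shown leave open whether the groups on the ring nitrogen differ at all in this read-out, since none of the three has a numerical value.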